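The source may report more compounds than this note shows. Statements on the series, on what has been measured and on what is new or still open speak of the compounds shown alone.

Compound 1 `CCCOC(=O)Nc1ccc([Se]C#N)cc1` gives 67500 nM in a functional assay on MCF7 cells (Homo sapiens) for cytotoxicity, read by MTT assay, with a stated time of 72 h; on this read-out lower numbers stand for higher toxicity in this test and higher numbers for lower toxicity in this test.
Compound 2 `CCOC(=O)Nc1ccc([Se]C#N)cc1` gives 67800 nM.
Compound 3 `O=C(Nc1ccc([Se][Se]c2ccc(NC(=O)OCc3ccccc3)cc2)cc1)OCc1ccccc1` gives 74500 nM.

Among these three numbers compound 2 stands second highest. Its nearest neighbour is compound 1 and its furthest is compound 3, yet all three values lie within the usual scatter of one another, so no order can be read into them. Compound 4 `CCCCCCOC(=O)Nc1ccc([Se]C#N)cc1` has not yet been tested in this assay. Compared with compound 2 the change is butyl in place of hydrogen on a saturated chain carbon, two bonds along the chain from an oxygen next to a carbonyl group. Within the data shown here, only one measured step touches this same place: the step from compound 1 to compound 2, which amounts to a 1.0-fold higher number from compound 1 to compound 2 (0.00 log units; within the scatter), a swap of methyl for hydrogen at exactly the carbon where butyl now enters. That step showed no movement beyond the scatter. Among the measured compounds shown here, the change toward compound 4 is larger in size, a chain of four carbons rather than one, and nothing among the measured compounds shows what a longer chain at this place does. For the measured compounds named here, with only that one small step as a guide, the expected step from compound 2 to compound 4 in this assay is a 1.0-fold higher number from compound 2 to compound 4 (0.00 log units; within the scatter), essentially no change beyond the scatter, while allowing a wide range for the untested chain length. Compound 4 is therefore estimated at 68000 nM, with a range from 30000 nM to 150000 nM.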

Compound 4, concentration lethal to 50% of the cells: 63900 nM
The estimate for compound 4 lay 1.1-fold (0.03 log units) above the measured number; measured number inside the range.
By their numbers in this assay, from the lowest: compounds 4, 1, 2 and 3 (each within the scatter of the next).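

In this assay, among these compounds, the earlier compounds tried only a methyl at this place, so it was unknown whether a much bigger piece would matter there; butyl now gives a 1.1-fold lower number from compound 2 to compound 4 (0.03 log units; within the scatter) and, counted from the propyl compound, propyl three bonds along the chain gives a 1.1-fold lower number from compound 1 to compound 4 (0.02 log units; within the scatter). Both steps stay within the usual scatter, so the ethyl, propyl and hexyl chains of compounds 2, 1 and 4 cannot be told apart in this test, and the number shows no dependence on chain length over this span. No measurement shown here offers any explanation for this.

On these data alone, it remains open whether a longer chain such as decyl, or a chain ending in an amine or a carboxylic acid, would carry the number beyond the scatter. These three compounds also say nothing about changes elsewhere on the shared core, and they cannot show whether the same flat picture would hold in any other cell line.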